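Cytotoxicity at the Assay Limit: a Dichlorophenyl Replacement

The source may hold more compounds than are shown below. What is called first, only, known or untested is meant among the compounds shown, and "the series" means these compounds.

Compound 1, `CC(C)N(Cc1cccc(OCCCCCC(=O)O)c1)C(=O)c1ccc(-c2cccc(-c3ccccc3)c2)cc1`, measured in an ADME assay on BJ cells (Homo sapiens) for cytotoxicity, read by CellTiter-Glo and resazurin assay, with a stated time of 72 h; a higher number here means that more compound is needed for the effect, a lower number that less compound is needed: a limit of the assay, > 26000 nM.
Compound 2, `CC(C)N(Cc1cccc(OCCCCCC(=O)O)c1)C(=O)c1ccc(-c2cccc(OC(F)(F)F)c2)cc1`, measured in this assay: a limit of the assay, > 26000 nM.

Both measured values are limits and not numbers, so the step that the two limits leave unreadable from compound 1 to compound 2 cannot be read. Within the data shown here, compound 2 therefore stands at the limit of this assay, and the one further value shown sits there too, as the limit of > 26000 nM in this assay, at which 2 of the 2 values shown sit, records. Compound 3, `CC(C)N(Cc1cccc(OCCCCCC(=O)O)c1)C(=O)c1ccc(-c2ccc(Cl)c(Cl)c2)cc1`, differs from compound 2 by 3,4-dichlorophenyl in place of 3-(trifluoromethoxy)phenyl on an aromatic carbon. Among the measured compounds shown here, the only measured step that bears on this change is a step that the two limits leave unreadable from compound 1 to compound 2, and its size is unreadable, so there is no basis for expecting a shift beyond the scatter in this assay in either direction. Compound 3 is accordingly expected to remain at the limit, with the estimated step that the limit leaves unreadable from compound 2 to compound 3 taken as none beyond the scatter. The estimate for compound 3 is 30000 nM, expected to lie between 18000 nM and 70000 nM.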

Compound 3, half-maximal effective concentration: > 26000 nM
Compound 3: a limit, no number; the forecaster's own chance of this, stated with the estimate: 85%; the middle value lies beyond the limit too.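

In this assay compound 3 gives > 26000 nM, a limit and not a number. No step among compound 1, compound 2 and compound 3 can therefore be read, and the limit is now shared: the limit of > 26000 nM in this assay, at which 3 of the 3 values shown sit.

The compounds shown leave open what concentration each would need for the effect, and so whether they differ at all.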